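Sulfonyl aryl variation on the shared core: compound 4

The compounds below may be only part of what the source reports. "The series", "measured", "known", "first", "only" and "open" are said of these compounds alone.

Among the compounds with values here, compound 1 `CN(C)/C=N/N=C/c1cn(S(=O)(=O)c2ccc(I)cc2)c2cccc([N+](=O)[O-])c12` gives 6340 nM in a functional assay on HEK293 cells for inhibition of 5-hydroxytryptamine receptor 6 (Homo sapiens), read by calcium flux and cAMP accumulation, with a stated time of 10 min (a higher number here means a weaker inhibitor, a lower number a stronger inhibitor), the highest of the three numbers measured so far; compound 2 `Cc1ccc(S(=O)(=O)n2cc(/C=N/N=C/N(C)C)c3c([N+](=O)[O-])cccc32)cc1` gives 2120 nM and compound 3 `COc1ccc(S(=O)(=O)n2cc(/C=N/N=C/N(C)C)c3c([N+](=O)[O-])cccc32)cc1` gives 740 nM. Compound 4 `COc1ccc(OC)c(S(=O)(=O)n2cc(/C=N/N=C/N(C)C)c3c([N+](=O)[O-])cccc32)c1` is not yet measured; its change from compound 1 is 2,5-dimethoxyphenyl in place of 4-iodophenyl on a sulfonyl sulfur. Within the data shown here, the steps that bear on it all alter the aryl on the sulfonyl sulfur: a 3.0-fold lower number from compound 1 to compound 2 (0.48 log units; beyond the scatter), an 8.6-fold lower number from compound 1 to compound 3 (0.93 log units; beyond the scatter) and a 2.9-fold lower number from compound 2 to compound 3 (0.46 log units; beyond the scatter). Among the measured compounds shown here, a methoxy-bearing aryl has so far given the largest gain over iodo, but the 2,5-dimethoxyphenyl has no measured precedent, so a lower number of uncertain size is expected. For compound 4 the expected step is a 4.2-fold lower number from compound 1 to compound 4 (0.63 log units; beyond the scatter). Compound 4 is therefore estimated at 1500 nM, with a range from 400 nM to 6000 nM.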

Compound 4, half-maximal inhibitory concentration: 1400 nM
Beside the measured number, compound 4's estimate is 1.1-fold (0.03 log units) above it, and the stated range covers the measured number.
By their numbers in this assay, from the lowest: compounds 3, 4 and 2 (each within the scatter of the next, the first and the last beyond it); then compound 1.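

In this assay, 2,5-dimethoxyphenyl on the sulfonyl sulfur keeps a gain over 4-iodophenyl (a 4.5-fold lower number from compound 1 to compound 4 (0.66 log units; beyond the scatter)), so a second methoxy-bearing aryl also stands beyond the scatter from the iodo compound. The two other aryls are not separated from it (a 1.9-fold higher number from compound 3 to compound 4 (0.28 log units; within the scatter); a 1.5-fold lower number from compound 2 to compound 4 (0.18 log units; within the scatter)), both steps lying within the scatter, so the added methoxy shows no measurable gain over the single 4-methoxyphenyl. No measurement available here accounts for these steps. Open, on these data alone, is whether an amine or a carboxylic acid on this aryl would keep or lose this level.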